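This account rests on a few compounds, and the source may have more. Where it says the series, first, only, none or still open, it means among the compounds named here.

Measured so far in a functional assay on the whole organism (stomach) with Rattus norvegicus as the target; on this read-out higher numbers stand for an effect only at larger amounts of compound and lower numbers for an effect already at smaller amounts:
- Compound 1 `CCCCCCC/N=C(\S)C1(c2ccccn2)CCCS1`: > 30 mg/kg, a limit
- Compound 2 `CCCCCCCCCCCC/N=C(\S)C1(c2ccccn2)CCCS1`: > 30 mg/kg, a limit
- Compound 3 `S=C(Nc1ccccc1)C1(c2ccccn2)CCCS1`: > 30 mg/kg, a limit

Compound 1 therefore has no exact number in this assay, only a limit. The same is true of compound 2 and compound 3, so the whole series stands at the limit of > 30 mg/kg in this assay, at which 3 of the 3 values shown sit.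

The next compound, compound 4 `CN(C)CCC/N=C(\S)C1(c2ccccn2)CCCS1`, keeps the core of compound 1 and changes its chain: dimethylamino in place of butyl on a saturated chain carbon, three bonds along the chain from a double-bonded nitrogen. In words, dimethylamino replaces butyl on a saturated chain carbon, three bonds along the chain from a double-bonded nitrogen. Cut one bond further out, the same difference reads heptyl to 3-(dimethylamino)propyl.

Among the compounds with values here, only one measured step bears on this change, the chain extension a step that the two limits leave unreadable from compound 1 to compound 2. It shows that a longer chain did not bring a number into view, but it offers no size to carry over. Within the data shown here, no compound measured so far carries a dimethylamino group. Another limit is the expected outcome for the new compound, with no step beyond the usual scatter. The expected step is a step that the limit leaves unreadable from compound 1 to compound 4. For compound 4 the estimated value is 40 mg/kg, with an expected range from 15 mg/kg to 100 mg/kg.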

Compound 4, dose for half-maximal effect: > 30 mg/kg
Compound 4: only a limit was reported; the forecaster's own chance of this, stated with the estimate: 70%; the middle value is on the limit's open side.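

Within the data shown here, compound 1 and compound 4 both carry only a limit in this assay, so no step between them can be read, and heptyl to 3-(dimethylamino)propyl has no size here. All four compounds share one result: the limit of > 30 mg/kg in this assay, at which 4 of the 4 values shown sit.

As far as these compounds go, whether any chain on the shared core would give an exact number in this assay stays open.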